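The source may hold more compounds than are shown below. What is called first, only, known or untested is meant among the compounds shown, and "the series" means these compounds.

Measured compounds in a functional assay on KB cells (Homo sapiens) for cytotoxicity; on this read-out higher numbers stand for an effect only at larger amounts of compound and lower numbers for an effect already at smaller amounts:
compound 1, `COC1=C(C)C(=O)/C(=C(O)/C=C/c2ccc(Br)cc2)C(=O)C1(C)C`, gives 1.7 ug/mL
compound 2, `COC1=C(C)C(=O)/C(=C(O)/C=C/c2ccc(F)cc2)C(=O)C1(C)C`, gives 3.7 ug/mL
compound 3, `COC1=C(C)C(=O)/C(=C(O)/C=C/c2c(C)cccc2C)C(=O)C1(C)C`, gives 7.1 ug/mL

Among these three, compound 1 stands lowest on this assay; its nearest neighbour is compound 2 and its furthest is compound 3, both with steps beyond the scatter. The step from compound 1 to compound 2 amounts to a 2.2-fold higher number from compound 1 to compound 2 (0.34 log units; beyond the scatter), and the step from compound 1 to compound 3 amounts to a 4.2-fold higher number from compound 1 to compound 3 (0.62 log units; beyond the scatter), while compounds 2 and 3 sit within the scatter of one another, as a 1.9-fold higher number from compound 2 to compound 3 (0.28 log units; within the scatter) shows.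

Compound 4, `C=Cc1ccccc1/C=C/C(O)=C1/C(=O)C(C)=C(OC)C(C)(C)C1=O`, is not yet measured. It differs from compound 1 in a single place: 2-vinylphenyl in place of 4-bromophenyl on a double-bonded chain carbon bound to a double-bonded chain carbon. Both steps already seen on the group at this place replaced the 4-bromophenyl of compound 1 and each raised the number: modestly for compound 2 and more so for compound 3. Among the compounds with values here, no measured pair tells about a vinyl group, so the estimate rests on those two steps alone. A modest rise beyond the scatter, between those two steps, is expected: for compound 4 the step is estimated at a 2.6-fold higher number from compound 1 to compound 4 (0.42 log units; beyond the scatter). Compound 4 is therefore expected to give about 4.5 ug/mL on this assay, with a range from 1.7 ug/mL to 12 ug/mL.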

Compound 4, concentration for half-maximal effect: 1.9 ug/mL
Beside the measured number, compound 4's estimate is 2.4-fold (0.37 log units) above it; measured number inside the range.
By their numbers in this assay, from the lowest: compounds 1, 4, 2 and 3 (each within the scatter of the next, the first and the last beyond it).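

In this assay, the 4-bromophenyl group can be exchanged at this place on the core without a shift beyond the scatter, with 2-vinylphenyl giving a 1.1-fold higher number from compound 1 to compound 4 (0.05 log units; within the scatter), whereas both earlier replacements had moved the number beyond it. A bromine atom is therefore not needed to keep a number in this range, since the entering group is made of carbon only, although the fluoro compound is also within the scatter of the new one, at a 1.9-fold lower number from compound 2 to compound 4 (0.29 log units; within the scatter). A substituted phenyl group whose name carries a 2 does not settle the outcome either, as the 2-vinylphenyl and 2,6-dimethylphenyl groups are separated by a 3.7-fold lower number from compound 3 to compound 4 (0.57 log units; beyond the scatter).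

Nothing given here explains why these groups read as they do in this cell assay.

The compounds shown leave open how the number would respond to an amine or a carboxylic acid on the phenyl ring at this place. They also leave open whether a longer chain in place of the vinyl group would keep the number within the scatter of compound 1.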